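Swapping the Ring-Carbon Arm: From Phenylethenyl to Dimethoxyphenyl

A few compounds are considered here, and "the series" means these few. Any claim that something is new, unique, unknown or untested is made for them only; others in the source may bear on it.

Compound 1, `Cc1cc(O)c(C2=NN(c3ccc(S(N)(=O)=O)cc3)C(c3ccccc3Cl)C2)cc1Cl`: 34300 nM
Compound 2, `Cc1cc(O)c(C2=NN(c3ccc(S(N)(=O)=O)cc3)C(/C=C/c3ccccc3)C2)cc1Cl`: 67200 nM

Both compounds share one core and differ only in the group on a saturated ring carbon. In a functional assay on ACHN cells (Homo sapiens) for antiproliferative activity, with a stated time of 48 h (a lower number here means that less compound is tolerated, a higher number that more compound is tolerated), compound 1 gives 34300 nM. In this assay compound 2 gives 67200 nM. Compound 2 cannot be told apart from compound 1 on these numbers: a 2.0-fold higher number from compound 1 to compound 2 (0.29 log units; within the scatter).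

Compound 3, `COc1ccc(C2CC(c3cc(Cl)c(C)cc3O)=NN2c2ccc(S(N)(=O)=O)cc2)cc1OC`, is not yet measured. It differs from compound 2 by 3,4-dimethoxyphenyl in place of 2-phenylethenyl on a saturated ring carbon. Going by the values given here, the only step on record, from compound 1 to compound 2, exchanged a group at this same saturated ring carbon and stayed within the scatter. Among the compounds with values here, no measured pair contains a 3,4-dimethoxyphenyl group, so the data give no direction for this change. The expected step is therefore none beyond the scatter, a 1.5-fold lower number from compound 2 to compound 3 (0.17 log units; within the scatter). For compound 3 the estimated value in this assay is 45000 nM, with a range from 15000 nM to 140000 nM.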

Compound 3, concentration lethal to 50% of the cells: > 100000 nM
Compound 3 ended at the assay's limit; the forecaster's own chance of this, stated with the estimate: 15%; middle value at least 2.2-fold (0.34 log units) from the limit.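

In this assay compound 3 gives > 100000 nM, which is a limit of the assay and not a number. Exchanging the group on this saturated ring carbon can move the result beyond the scatter, as 3,4-dimethoxyphenyl in place of 2-chlorophenyl gives an at least 2.9-fold higher number from compound 1 to compound 3 (0.46 log units; beyond the scatter), and with it more compound is tolerated. In place of 2-phenylethenyl, the same group gives only a floor, an at least 1.4-fold higher number from compound 2 to compound 3 (0.17 log units; that floor lies within the scatter), so the true size of this step stays hidden at the top of the range: the limit of > 100000 nM in this assay, at which 1 of the 3 values shown sits.

The compounds shown leave open how much of the change comes from the two methoxy groups, since none carries a phenyl ring with a single methoxy. They also leave open whether an amine or a carboxylic acid on this ring carbon would lower the number.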